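The source may report more compounds than this note shows. Statements on the series, on what has been measured and on what is new or still open speak of the compounds shown alone.

Compound 1 `Cc1nc(N)nc2c1c(-c1ccc3oc(N)nc3c1)nn2C(C)C` and compound 2 `CCc1nc(N)nc2c1c(-c1ccc3oc(N)nc3c1)nn2C(C)C` share one core; compound 2 differs from compound 1 only by a methyl in place of hydrogen on a saturated chain carbon bound to an aromatic carbon. In an ADME assay on cells (Hepatocyte, Homo sapiens) for metabolic stability, read by LC-MS, with a stated time of 90 min, tested at 1 uM (on this read-out higher numbers stand for fast clearance and lower numbers for slow clearance), compound 1 gives < 5 uL/min, which is a limit of the assay and not a number. In this assay compound 2 gives < 5 uL/min, again a limit rather than a number. The step that the two limits leave unreadable from compound 1 to compound 2 therefore cannot be sized, because the limit of < 5 uL/min in this assay, at which 2 of the 3 values shown sit, takes in both values. Compound 3 `COc1nc(N)nc2c1c(-c1ccc3oc(N)nc3c1)nn2C(C)C` carries a methoxy instead; for compound 3 the outcome in this assay is "not determined" (no result reported), so no number at all is known for it. Compound 4 `CC(C)n1nc(-c2ccc3oc(N)nc3c2)c2c(Br)nc(N)nc21` is the next compound to be tested: bromo in place of methoxy on an aromatic carbon. No measured step bears directly on this change, and the one step shown is unreadable. With its two measured relatives both sitting at the limit, compound 4 is expected to remain slowly cleared as well, at an estimated 4 uL/min, within 1 uL/min to 12 uL/min.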

Compound 4, intrinsic clearance in a liver preparation (reported as CLH), per the amount of preparation that the assay uses: 55 uL/min
The estimate for compound 4 lay 14-fold (1.14 log units) below the measured number, and the stated range ends below it.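

In this assay, the group on the aromatic carbon next to the ring nitrogen turns out to matter a great deal: bromo in place of ethyl gives an at least 11-fold higher number from compound 2 to compound 4 (1.04 log units; beyond the scatter), and bromo in place of methyl gives an at least 11-fold higher number from compound 1 to compound 4 (1.04 log units; beyond the scatter). Both steps start from a limit of the assay and not from a number: the limit of < 5 uL/min in this assay, at which 2 of the 4 values shown sit. The earlier step from methyl to ethyl could not be read, so only now does a change at this position show up as a clear difference in clearance.

Compound 3 has no result, so the change from methoxy to bromo has no size of its own. The compounds shown also leave open whether the higher number is particular to bromo, or whether chloro, a nitrile or an amine at this position would give a similar one.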